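Swapping Methoxy for Bromo on a Shared Core

A few compounds are considered here, and "the series" means these few. Any claim that something is new, unique, unknown or untested is made for them only; others in the source may bear on it.

Compound 1, `COc1ccc(-c2ccnc(Nc3ccc(Cl)cc3Cl)n2)cc1`: 4170 nM
Compound 2, `COc1ccc(-c2ccnc(Nc3ccc([N+](=O)[O-])cc3)n2)cc1`: 770 nM
Compound 3, `Clc1ccc(Nc2nccc(-c3ccc(Cl)cc3Cl)n2)c(Cl)c1`: 3180 nM

In a functional assay on MCF7 cells (Homo sapiens) for antiproliferative activity, read by MTT assay (on this read-out lower numbers stand for stronger inhibition and higher numbers for weaker inhibition), compound 2 gives the lowest of the three numbers; compound 3 sits above it and compound 1 higher still, both gaps beyond the usual scatter. Compound 4, `O=[N+]([O-])c1ccc(Nc2nccc(-c3ccc(Br)cc3)n2)cc1`, keeps the core of compound 2 and differs in one place: bromo in place of methoxy on an aromatic carbon. For the measured compounds named here, no measured pair shows this exchange, so its size is unknown. The expectation is a step from compound 2 to compound 4 of a 1.3-fold higher number from compound 2 to compound 4 (0.11 log units; within the scatter) in this assay, which is no change beyond the scatter or a mild weakening. Compound 4 is therefore expected to give 1000 nM in this assay, with a likely range from 350 nM to 3000 nM.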

Compound 4, half-maximal inhibitory concentration: 681000 nM
Beside the measured number, compound 4's estimate is 680-fold (2.83 log units) below it; the whole stated range lies below it.
By their numbers in this assay, from the lowest: compound 2; then compounds 3 and 1 (each within the scatter of the next); then compound 4.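

In this assay the exchange of methoxy for bromo on an aromatic carbon gives an 880-fold higher number from compound 2 to compound 4 (2.95 log units; beyond the scatter) and so shows that this place is far from indifferent to what sits on it. For the compounds shown here, the earlier compounds held no pair differing in one place, so this is the first direct view of how much a single group can matter on this core. Nothing available explains the size of this step.

On these data alone, whether ethoxy, hydroxyl or an amine here would stay close to compound 2 or fall away like compound 4 remains open. So does whether the same exchange would have a similar effect on a different core.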